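Little Movement Expected on Losing the Larger Ring Group

The compounds below may be only part of what the source reports. "The series", "measured", "known", "first", "only" and "open" are said of these compounds alone.

In an ADME assay on AD293 cells (Homo sapiens) for cytotoxicity (a lower number here means that less compound is tolerated, a higher number that more compound is tolerated), compound 3 `C=C1CC[C@H]2[C@@](C)(CCC(=O)[C@@]2(C)CO[Si](C)(C)C(C)(C)C)[C@@H]1C/C=C1/C(=O)OC[C@@H]1OC(C)=O` gives 8230 nM, which lies within the scatter of compound 2 `C=C1CC[C@H]2[C@@](C)(CCC(=O)[C@@]2(C)CO[Si](C)(C)C(C)(C)C)[C@@H]1C/C=C1/C(=O)OC[C@H]1OC(C)=O` at 7350 nM and of compound 1 `C=C1CC[C@@H]2[C@](C)(CO[Si](C)(C)C(C)(C)C)[C@H](O)CC[C@@]2(C)[C@@H]1C/C=C1/C(=O)OC[C@H]1OC(C)=O` at 7330 nM. The three measured compounds therefore form a single tight group on this read-out.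

The next compound to be tested is compound 4 `C=C1CC[C@H]2[C@@](C)(CCC(=O)[C@@]2(C)CO[Si](C)(C)C(C)(C)C)[C@@H]1C/C=C1/C(=O)OC[C@H]1O`. Its difference from compound 3 is a group of 8 heavy atoms (5 carbon, 3 oxygen; one five-membered non-aromatic ring with 1 hetero atom) in place of a group of 11 heavy atoms (7 carbon, 4 oxygen; one five-membered non-aromatic ring with 1 hetero atom), on a saturated chain carbon bound to a saturated ring carbon. A group of 8 heavy atoms replaces a group of 11 heavy atoms, and each contains one five-membered non-aromatic ring with 1 hetero atom.

Among the compounds with values here, only one measured step links two compounds that differ in one place. That step is a 1.1-fold higher number from compound 2 to compound 3 (0.05 log units; within the scatter), and it stands with the fact that compounds 2 and 3 differ only in the configuration as drawn. It stays within the scatter, but it concerns configuration alone. Within the data shown here, no measured step exchanges the group that leaves here, since all three tested compounds still carry it, so the data give no direct size for this change.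

The expectation therefore rests on the narrow spread of the three values, with compound 3 at 8230 nM as the starting point, and no shift beyond the scatter is anticipated in either direction. The estimated step is a 1.0-fold lower number from compound 3 to compound 4 (0.01 log units; within the scatter). Compound 4 is estimated at 8000 nM, with an expected range from 3500 nM to 18000 nM.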

Compound 4, half-maximal cytotoxic concentration: 2350 nM
Beside the measured number, compound 4's estimate is 3.4-fold (0.53 log units) above it, outside the stated range (below it).
By their numbers in this assay, from the lowest: compound 4; then compounds 1, 2 and 3 (each within the scatter of the next).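

In this assay, the exchange at this oxygen is the first change among these compounds to move the number beyond the scatter: hydrogen in place of acetyl on an oxygen on a saturated carbon gives a 3.1-fold lower number from compound 2 to compound 4 (0.50 log units; beyond the scatter). The other route to the same compound, a 3.5-fold lower number from compound 3 to compound 4 (0.54 log units; beyond the scatter), points the same way and is of similar size, so less of compound 4 is tolerated in this assay than of either acetyl-bearing partner. The earlier step had shown only that the configuration drawn at this saturated ring carbon leaves the number within the scatter while the acetyl stays in place, and the two new steps can therefore be read as one result for the loss of the acetyl:  the fact that compounds 2 and 3 differ only in the configuration as drawn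

On these data alone, what remains open is whether the shift follows from losing the acetyl as such or from having hydrogen on that oxygen, and a methyl ether or a propanoyl ester at the same oxygen would separate the two. As far as these compounds go, it is also open whether hydrogen on that oxygen gives a similar number with the opposite configuration at the ring carbon, or on the core of compound 1.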